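A smaller thiophene in a cell tolerance test

This account rests on a few compounds, and the source may have more. Where it says the series, first, only, none or still open, it means among the compounds named here.

In an ADME assay on Vero cells (Chlorocebus sabaeus) for cytotoxicity, read by MTT assay, with a stated time of 96 h (a higher number here means that more compound is tolerated, a lower number that less compound is tolerated), compound 1 `COc1cc(NCc2ccc(C)o2)ccc1-c1cnco1` gives 45200 nM and compound 2 `CCc1ccc(CNc2ccc(-c3cnco3)c(OC)c2)s1` gives 13600 nM as the lower of the two numbers. Compound 3 `COc1cc(NCc2ccsc2)ccc1-c1cnco1` is not yet measured and differs from compound 2 by thiophen-3-yl in place of 5-ethylthiophen-2-yl on a saturated chain carbon bound to a nitrogen on an aromatic ring on a saturated chain carbon bound to a nitrogen on an aromatic ring. Within the data shown here, the only measured step at that place is a 3.3-fold lower number from compound 1 to compound 2 (0.52 log units; beyond the scatter) and it is modest. With that one step as the guide, a 1.8-fold higher number from compound 2 to compound 3 (0.26 log units; within the scatter) is the expected move in this assay and it stays smaller than the measured one. Compound 3 is expected at 25000 nM with a range of 10000 nM to 60000 nM around that estimate.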

Compound 3, half-maximal cytotoxic concentration: 181000 nM
Beside the measured number, compound 3's estimate is 7.2-fold (0.86 log units) below it; the measured number lies above the stated range.
By their numbers in this assay, from the lowest: compound 2; then compound 1; then compound 3.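

In this assay the swap to thiophen-3-yl brings a 13-fold higher number from compound 2 to compound 3 (1.12 log units; beyond the scatter) and also a 4.0-fold higher number from compound 1 to compound 3 (0.60 log units; beyond the scatter) at the same place, so compound 3 stands highest of the three. This single position can therefore move the number both down and up, and by far more than the first step suggested. Nothing measured here explains the jump.
The swap from 5-ethylthiophen-2-yl both removes the ethyl and changes the ring's point of attachment, and the compounds shown do not separate these two changes. A plain thiophen-2-yl or a phenyl ring at this place would be the next groups to compare.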